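The source may hold more compounds than are shown below. What is called first, only, known or untested is meant among the compounds shown, and "the series" means these compounds.

In a functional assay (muscle tissue) with Cavia porcellus as the target (on this read-out lower numbers stand for an effect already at smaller amounts and higher numbers for an effect only at larger amounts of compound), compound 3 `COC(=O)C1=C(C)N=C(C)/C(=C(\O)OC)C1c1cccc(N)c1` gives 2000 nM, the highest of the three numbers at hand. Compound 1 `COC(=O)C1=C(C)N=C(C)/C(=C(\O)OC)C1c1cccc(N(C)C)c1` gives 891 nM, and compound 2 `COC(=O)C1=C(C)N=C(C)/C(=C(\O)OC)C1c1ccccc1OC` gives 57.5 nM. Among the measured compounds shown here, the step of a 2.2-fold higher number from compound 1 to compound 3 (0.35 log units; beyond the scatter) is modest, whereas the step of a 35-fold higher number from compound 2 to compound 3 (1.54 log units; beyond the scatter) is large; the latter is the one that changes the aryl group on the saturated ring carbon, and so it is the closer precedent for the next step.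

Compound 4 `COC(=O)C1=C(C)N=C(C)/C(=C(\O)OC)C1c1ccc(Br)cc1` differs from compound 3 as follows: 4-bromophenyl in place of 3-aminophenyl on a saturated ring carbon. For the measured compounds named here, the 4-bromophenyl carries neither the hydrogen-bond donor nor the hydrogen-bond acceptor of the 3-aminophenyl, and no measured compound carries a 4-bromophenyl, so the direction can be read only loosely from the spread between compound 2 and compound 3. A step in this assay beyond the scatter is expected, in either direction, with the lower number somewhat more likely because compound 3 already gives 2000 nM at the top of the set. For compound 4 the expected value is 900 nM, with a range of 150 nM to 5000 nM. The step this estimate implies is a 2.2-fold lower number from compound 3 to compound 4 (0.35 log units; beyond the scatter).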

Compound 4, half-maximal effective concentration: 540 nM
Estimate against measurement, compound 4: 1.7-fold (0.22 log units) above, and the stated range covers the measured number.
By their numbers in this assay, from the lowest: compound 2; then compounds 4 and 1 (each within the scatter of the next); then compound 3.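

The aryl group on this saturated ring carbon can lose the amino group without the number in this assay rising: replacing 3-aminophenyl with 4-bromophenyl gives a 3.7-fold lower number from compound 3 to compound 4 (0.57 log units; beyond the scatter), and the entering group has 0 hydrogen-bond donors and 0 hydrogen-bond acceptors. The same group still leaves a 9.4-fold higher number from compound 2 to compound 4 (0.97 log units; beyond the scatter), so removing the amino group in favour of bromine does not recover the level of the 2-methoxyphenyl in compound 2. No measurement at hand accounts for either step.

The step from compound 3 to compound 4 changes both the substituent and its place on the phenyl, so the compounds shown do not separate the two. Also open, as far as these compounds go, is how an unsubstituted phenyl, a 2-bromophenyl or a 3-nitrophenyl would read at this carbon.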